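A few compounds are considered here, and "the series" means these few. Any claim that something is new, unique, unknown or untested is made for them only; others in the source may bear on it.

Compound 1 `Cc1cc(NCc2ccccn2)n2ncc(-c3cccc(Cl)c3)c2n1` sits at a limit in a physicochemical assay for solubility, read by HPLC, using the shake flask method, measured as kinetic solubility, with a stated time of 2 h, at pH 7.4; a higher number here means a more soluble compound, a lower number a less soluble compound: compound 1 gives < 5000 nM, which is a limit of the assay rather than a measured number, as the limit of < 5000 nM in this assay, at which 1 of the 3 values shown sits, records. Two other compounds share the same core. Compound 2 `Cc1cc(NCc2ccccn2)n2nc(C)cc2n1` also returns a limit in this assay, giving > 200000 nM, noted in the limit of > 200000 nM in this assay, at which 1 of the 3 values shown sits. Compound 3 `Cc1cc(NCc2cccc[n+]2[O-])n2ncc(-c3ccccc3)c2n1` gives a measured solubility of 159000 nM in this assay. Compound 1 therefore stands at the low end of the three values shown, while compound 2 and compound 3 stand far above it.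

Compound 4 `Cc1cc(NCc2ccccn2)n2ncc(-c3cncnc3)c2n1` has not yet been measured. It differs from compound 1 in one place: pyrimidin-5-yl in place of 3-chlorophenyl on an aromatic carbon. Among the measured compounds shown here, no step between two measured compounds carries this same change, so the expected size rests only on the spread among compound 1, compound 2 and compound 3. The step from compound 1 to compound 4 is expected to raise solubility, estimated as an at least 6.0-fold higher number from compound 1 to compound 4 (0.77 log units; beyond the scatter), well beyond the scatter. Compound 4 is accordingly estimated at 30000 nM, with a likely range from 8000 nM to 120000 nM.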

Compound 4, solubility: 111000 nM
Compound 4: middle estimate off by 3.7-fold (0.57 log units), on the low side; measured number inside the range.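

Pyrimidin-5-yl in place of 3-chlorophenyl on this aromatic carbon of the shared core gives, in this assay, an at least 22-fold higher number from compound 1 to compound 4 (1.34 log units; beyond the scatter), a step beyond the scatter. Among the compounds shown here, the earlier compounds differ from compound 1 in more than one place, so only this pair ties a large shift to this single position, with the rest of the structure kept the same. The size of the step is a lower bound and not an exact figure, because compound 1 sits at a limit of the assay: the limit of < 5000 nM in this assay, at which 1 of the 4 values shown sits.

The compounds shown leave open whether the gain comes from losing the chlorine or from gaining the ring nitrogens, since both change together in this one step. Also open, from the compounds shown here alone, is how a pyridin-3-yl ring or a morpholine on the same aromatic carbon would read in this assay.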